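Indolyl-indazole series: sulfonyl replacements on the ring nitrogen

The compounds below may be only part of what the source reports. "The series", "measured", "known", "first", "only" and "open" are said of these compounds alone.

Measured compounds:
compound 1 `CN(C(=O)c1ccccc1)c1ccc2[nH]c(-c3n[nH]c4ccccc34)cc2n1`, 10600 nM
compound 2 `CN(C(=O)CCc1ccccc1)c1ccc2[nH]c(-c3n[nH]c4ccccc34)cc2n1`, 11200 nM
compound 3 `CN(c1ccc2[nH]c(-c3n[nH]c4ccccc34)cc2n1)S(=O)(=O)c1ccccc1`, 6740 nM

In a functional assay on HCT-116 cells (Homo sapiens) for antiproliferative activity, read by MTT assay, with a stated time of 72 h (a lower number here means a stronger inhibitor, a higher number a weaker inhibitor), compound 2 gives the highest of the three numbers, but its gaps to compound 1 and compound 3 are within the scatter, so no ordering among them can be claimed. Compound 4 `CN(c1ccc2[nH]c(-c3n[nH]c4ccccc34)cc2n1)S(=O)(=O)c1ccc(Br)cc1` differs from compound 2 as follows: (4-bromophenyl)sulfonyl in place of phenethylcarbonyl on a nitrogen on an aromatic ring. Among the measured compounds shown here, the steps that bear on this change are a 1.7-fold lower number from compound 2 to compound 3 (0.22 log units; within the scatter) and a 1.6-fold lower number from compound 1 to compound 3 (0.20 log units; within the scatter), both within the scatter; the bromine on the entering group has no precedent here. The step of a 1.9-fold lower number from compound 2 to compound 4 (0.27 log units; within the scatter) is therefore expected to be small, leaning towards a lower number. Compound 4 is estimated at 6000 nM, with a range of 2500 nM to 14000 nM.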

Compound 4, half-maximal inhibitory concentration: 9850 nM
Compound 4: middle estimate off by 1.6-fold (0.22 log units), on the low side; measured number inside the range.
By their numbers in this assay, from the lowest: compounds 3, 4, 1 and 2 (each within the scatter of the next).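

In this assay, bromo in place of hydrogen on an aromatic carbon gives a 1.5-fold higher number from compound 3 to compound 4 (0.16 log units; within the scatter) and so does not separate compound 4 from compound 3. The (4-bromophenyl)sulfonyl group is likewise not separated from either carbonyl group, with a 1.1-fold lower number from compound 2 to compound 4 (0.06 log units; within the scatter) against phenethylcarbonyl and a 1.1-fold lower number from compound 1 to compound 4 (0.03 log units; within the scatter) against benzoyl, so all four groups at this nitrogen remain within the scatter of their listed partners. No available evidence bears on these results.

Still open, going by these compounds, is whether an amine or a carboxylic acid in place of the bromo would move the number beyond the scatter. Also open, on these data alone, is whether any group on this nitrogen can do so.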